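This account rests on a few compounds, and the source may have more. Where it says the series, first, only, none or still open, it means among the compounds named here.

Measured compounds:

Compound 1, `CCCS(=O)(=O)Nc1ccc(F)c(C(=O)c2n[nH]c3ncc(-c4ccc(OC)cc4)cc23)c1F`, in an assay for binding affinity to dual specificity mitogen-activated protein kinase kinase 4 (Homo sapiens), read by KINOMEscan, tested at 100 nM (on this read-out higher numbers stand for a weaker effect at the one concentration tested and lower numbers for a stronger effect), compound 1 gives 4.2%.
Compound 2, `CCCS(=O)(=O)Nc1ccc(F)c(C(=O)c2n[nH]c3ncc(-c4ccc(O)cc4)cc23)c1F`, in this assay compound 2 gives 0.75%.
Compound 3, `CCCS(=O)(=O)Nc1ccc(F)c(C(=O)c2n[nH]c3ncc(-c4cccc(N(C)C)c4)cc23)c1F`, in this assay compound 3 gives 26%.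

Compound 3 stands at the top of the three numbers; the step of a number 21.8 percentage points higher from compound 1 to compound 3 (beyond the scatter) and the step of a number 25.3 percentage points higher from compound 2 to compound 3 (beyond the scatter) both lie beyond the scatter, so compound 3 is the weakest binder of the set at this concentration, while the step of a number 3.5 percentage points lower from compound 1 to compound 2 (within the scatter) is within the scatter and compounds 1 and 2 cannot be ordered.

Compound 4 is `CCCS(=O)(=O)Nc1ccc(F)c(C(=O)c2n[nH]c3ncc(-c4ccc(F)cc4C)cc23)c1F`, not yet measured. It differs from compound 3 in one place: 4-fluoro-2-methylphenyl in place of 3-(dimethylamino)phenyl on an aromatic carbon.

The bearing steps are the two that lead into compound 3, from compounds 1 and 2, which each carry a six-membered aromatic ring of carbon only at the same place and which both give modest rises to the 3-(dimethylamino)phenyl. Removing that group in compound 4 is expected to reverse much of that rise, so a moderate downward step is expected in this assay, a number 18 percentage points lower from compound 3 to compound 4 (beyond the scatter). Going by the values given here, no measured compound carries 4-fluoro-2-methylphenyl, so the estimate rests only on compounds 1 and 2. Compound 4 is expected to give 8%, in the range 1.5% to 30%.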

Compound 4, a percentage reported as activity, at one concentration (the size of the read-out at that concentration, not a potency): 14%
Compound 4: middle estimate off by 6 percentage points, on the low side; the range from low to high includes it.
By their numbers in this assay, from the lowest: compounds 2, 1 and 4 (each within the scatter of the next, the first and the last beyond it); then compound 3.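

In this assay, the position para to a fused ring does not depend on an oxygen substituent or on a hydrogen-bond acceptor in the entering group: 4-fluoro-2-methylphenyl has neither, and a number 9.8 percentage points higher from compound 1 to compound 4 (within the scatter) cannot be told apart from the 4-methoxyphenyl result. The weak result of the 3-(dimethylamino)phenyl is also not a general outcome of changing the 4-oxygen group, since a number 12 percentage points lower from compound 3 to compound 4 (beyond the scatter) recovers part of the gap, yet 4-hydroxyphenyl still holds a real margin, with a number 13.3 percentage points higher from compound 2 to compound 4 (beyond the scatter) as the cost of leaving it. No measurement bears on why these groups differ.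

Since 4-fluoro-2-methylphenyl brings in its fluorine and its methyl together, the contribution of each stays unresolved, and the same ring with the methyl alone or the fluorine alone would separate them. As far as these compounds go, it is also open whether the loss with 3-(dimethylamino)phenyl follows from the dimethylamino group itself or from where it sits on the ring, which a primary amine or a methoxy group at that same ring place could help to test.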